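The compounds below may be only part of what the source reports. "The series", "measured", "known", "first", "only" and "open" are said of these compounds alone.

Of the compounds shown here, three sharing a common core have been tested in a physicochemical assay, read by spectrophotometry, with a stated time of 15 min; on this read-out lower numbers stand for stronger inhibition and higher numbers for weaker inhibition. Compound 2 `O=C(CCCc1nc2ccccc2c(=O)[nH]1)N/N=C/c1cc(O)c(O)c(O)c1` gives 45000000 nM. Among the measured compounds shown here, compound 3 `COc1cc(/C=N/NC(=O)CCCc2nc3ccccc3c(=O)[nH]2)cc(OC)c1OC` gives 85000000 nM, a number that lies within the scatter of the one for compound 2. Compound 1 `O=C(CCc1nc2ccccc2c(=O)[nH]1)N/N=C/c1ccc(O)c(O)c1` gives 105000000 nM, which is higher than the number for compound 2 by more than the scatter.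

The next compound to consider is compound 4 `O=C(CCCc1nc2ccccc2c(=O)[nH]1)N/N=C/c1ccc(O)c(O)c1`, which has not yet been measured. It departs from compound 2 in one place: hydrogen in place of hydroxy on an aromatic carbon. In words, hydrogen stands in place of hydroxy on an aromatic carbon, so 3,4,5-trihydroxyphenyl becomes 3,4-dihydroxyphenyl. For the measured compounds named here, no two measured compounds differ in just one place, so the data hold no direct precedent for this change. With compound 2 at 45000000 nM and compound 1 at 105000000 nM, the measured numbers span only a narrow band, so a modest step is expected, about the size of the scatter and towards a higher number. The expected step is a 1.6-fold higher number from compound 2 to compound 4 (0.19 log units; within the scatter). For compound 4 the estimated value is 70000000 nM, with an expected range from 35000000 nM to 140000000 nM.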

Compound 4, half-maximal inhibitory concentration: 75000000 nM
Compound 4: middle estimate off by 1.1-fold (0.03 log units), on the low side; measured number inside the range.
By their numbers in this assay, from the lowest: compounds 2, 4, 3 and 1 (each within the scatter of the next, the first and the last beyond it).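

Among the compounds shown here, compounds 2 and 4 form the first pair here that differs in only one place, so this change can now be read directly. In this assay swapping hydroxy for hydrogen on the aromatic carbon gives a 1.7-fold higher number from compound 2 to compound 4 (0.22 log units; within the scatter) and so leaves the number within the scatter of repeated measurements. At this position, ortho to one hydroxy group and meta to another, the 3,4,5-trihydroxyphenyl and 3,4-dihydroxyphenyl rings therefore cannot be told apart in this read-out, and no separate measurement is available to help interpret the result.

This single step covers only hydrogen and hydroxy at one position on the ring, so it cannot show whether a group of another kind there, such as an amine, a fluorine atom or a carboxylic acid, would move the number beyond the scatter. It also leaves open what would happen if a further hydroxy group were replaced by hydrogen, leaving a 3-hydroxyphenyl or 4-hydroxyphenyl ring, or if all of them were.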